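The source may hold more compounds than are shown below. What is called first, only, known or untested is meant among the compounds shown, and "the series" means these compounds.

Compound 1, `CC(O)(CSc1ccc(Cl)cc1)c1nc(-c2ccc(Cl)cc2)no1`, carries a chloro on an aromatic carbon of a six-membered aromatic ring of carbon only, para to a large group. Going by the values given here, in a functional assay on DU-145 cells (Homo sapiens) for cytotoxicity, read by MTT assay (a higher number here means a weaker inhibitor, a lower number a stronger inhibitor), compound 1 gives 14500 nM, the only plain number in this set. Compound 2, `CC(O)(CS(=O)(=O)c1ccc(Br)cc1)c1nc(-c2ccccc2)no1`, is the other tested compound. In this assay compound 2 gives > 100000 nM, which is a limit of the assay rather than a number. This matches (the limit of > 100000 nM in this assay, at which 1 of the 2 values shown sits). Compound 3, `CC(O)(CSc1ccc(Cl)cc1)c1nc(-c2ccccc2)no1`, has not yet been measured and differs from compound 1 in one place: hydrogen in place of chloro on an aromatic carbon. Among the compounds with values here, no step between two measured compounds is available to guide the size of this change, and compound 2 differs from compound 1 in more than one place. A modest weakening is expected, a step of a 2.1-fold higher number from compound 1 to compound 3 (0.32 log units; beyond the scatter), which may still sit within the usual scatter. Compound 3 is therefore estimated at 30000 nM, within a range from 10000 nM to 100000 nM.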

Compound 3, half-maximal inhibitory concentration: 70700 nM
Estimate against measurement, compound 3: 2.4-fold (0.37 log units) below; low and high end bracket the measured number.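

Going by these compounds alone, with the rest of compound 1 held fixed, changing 4-chlorophenyl to phenyl gives the first step in this set that can be read at a single place: in this assay, the change brings a 4.9-fold higher number from compound 1 to compound 3 (0.69 log units; beyond the scatter). This shows that the chloro at this place matters for cytotoxicity in these cells, with compound 3 the weaker of the pair. Compound 3 still gives a plain number, and the step is therefore not cut off at the top of the measurable range: the limit of > 100000 nM in this assay, at which 1 of the 3 values shown sits.

The compounds shown do not tell whether chloro is special here or whether a fluoro, a methyl or a methoxy at the same place would serve as well or better. Within the data shown here, the other chloro of compound 1 also has no step of its own, and its contribution remains unknown.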